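Benzyl on the core of compound 1

The compounds below may be only part of what the source reports. "The series", "measured", "known", "first", "only" and "open" are said of these compounds alone.

Going by the values given here, in a functional assay on A549 cells (Homo sapiens) for cytotoxicity, with a stated time of 48 h (on this read-out higher numbers stand for weaker inhibition and lower numbers for stronger inhibition), compound 1 `C[S+]([O-])/C=C/c1cc(=O)c2ccccc2o1` gives 1900 nM, the only true number so far. Compound 2 `C[S+]([O-])/C=C/c1cc(=O)c2cc(C#N)ccc2o1` reads > 10000 nM in this assay, which is a limit and not a number. Compound 3 `C[S+]([O-])/C=C/c1oc2ccccc2c(=O)c1Cc1ccccc1` differs from compound 1 by benzyl in place of hydrogen on an aromatic carbon, so benzyl takes the place of a hydrogen on an aromatic carbon.

Among the compounds with values here, only one measured step bears on this change: an at least 5.2-fold higher number from compound 1 to compound 2 (0.72 log units; beyond the scatter), with cyano in place of hydrogen on an aromatic carbon. That step moved towards weaker inhibition, but it involves a different group and is a single example, so it serves only as a loose guide. A modest move in the same direction is therefore expected in this assay, smaller than the cyano step, and a result within the scatter of compound 1 remains possible. The expected step is a 1.8-fold higher number from compound 1 to compound 3 (0.27 log units; within the scatter). For compound 3 the estimated value is 3500 nM, with an expected range of 900 nM to 10000 nM.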

Compound 3, half-maximal inhibitory concentration: 1300 nM
Estimate against measurement, compound 3: 2.7-fold (0.43 log units) above; low and high end bracket the measured number.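

In this assay, benzyl in place of hydrogen on an aromatic carbon gives a 1.5-fold lower number from compound 1 to compound 3 (0.16 log units; within the scatter) and so leaves compound 3 level with compound 1 within the scatter. Going by these compounds alone, this is the first reading at this position, two atoms from the ring oxygen, and it shows that a group of 7 heavy atoms with a six-membered aromatic ring can stand there while the read-out stays a true number. Substitution on the core of compound 1 therefore does not by itself weaken inhibition, and the cyano change stays the only step beyond the scatter, read against a limit in compound 2: the limit of > 10000 nM in this assay, at which 1 of the 3 values shown sits.

Within the data shown here, with benzyl as the only group at this position, it remains open whether the flat result holds for a methyl, a longer alkyl chain, an amine or a carboxylic acid on the same carbon. Also open is whether a hydroxyl or a methoxy on the benzyl ring would shift the number, and the compounds shown give no cause for either step.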